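The source may report more compounds than this note shows. Statements on the series, on what has been measured and on what is new or still open speak of the compounds shown alone.

Working notes on the series. Two compounds have numbers in a functional assay on P388 cells (Mus musculus) for inhibition, tested at 10 uM; on this read-out higher numbers stand for a stronger effect at the one concentration tested and lower numbers for a weaker effect. Compound 1 `Cc1ccc(S(=O)(=O)n2cc(-c3cc(C(F)(F)F)cc(-c4cn(S(=O)(=O)c5ccc(C)cc5)c5cc(Br)ccc45)n3)c3ccc(Br)cc32)cc1` gives 15.1% in this assay. Compound 2 `COc1ccc2c(-c3cc(C(F)(F)F)cc(-c4cn(S(=O)(=O)c5ccc(C)cc5)c5cc(OC)ccc45)n3)cn(S(=O)(=O)c3ccc(C)cc3)c2c1` gives 92.8% in this assay. Compound 1 thus stands lowest of the two numbers; the nearest and only other number, that of compound 2, lies well above it, beyond the scatter. Within the data shown here, compounds 1 and 2 differ in more than one place, so no single step between them is counted, and only their two values are noted.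

Compound 3 `Cc1ccc(S(=O)(=O)n2cc(-c3cc(C(F)(F)F)c(C#N)c(-c4cn(S(=O)(=O)c5ccc(C)cc5)c5cc(Br)ccc45)n3)c3ccc(Br)cc32)cc1` has not been measured in this assay. Compared with compound 1 the change is cyano in place of hydrogen on an aromatic carbon, on the six-membered aromatic ring with one nitrogen, ortho to a trifluoromethyl group. Among the measured compounds shown here, no measured pair with a change of this kind exists, so the expectation rests on compound 1 alone. A step from compound 1 to compound 3 of a number 8.9 percentage points higher from compound 1 to compound 3 (within the scatter) is expected in this assay, probably not beyond the scatter. For compound 3 the estimate in this assay is 24%, within 5% to 60%.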

Compound 3, a percentage reported as inhibition, at one concentration (the size of the read-out at that concentration, not a potency): 5.7%
Beside the measured number, compound 3's estimate is 18.3 percentage points above it; low and high end bracket the measured number.
By their numbers in this assay, from the lowest: compounds 3 and 1 (each within the scatter of the next); then compound 2.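

Among these compounds, this is the first step that can be read at a single place: in this assay, cyano in place of hydrogen on an aromatic carbon of the six-membered aromatic ring with 1 nitrogen, ortho to a trifluoromethyl group and two atoms from the ring nitrogen, gives a number 9.4 percentage points lower from compound 1 to compound 3 (within the scatter). At this position, therefore, the read-out does not separate cyano from hydrogen, and the added nitrile does not lift compound 3 out of the range of compound 1 at the one concentration tested. The series holds no measurement that bears on the reason for this result, and the step is a single pair on one core, so it supports no wider rule about this carbon.

Whether an amine, a carboxylic acid or a primary amide on this same aromatic carbon would give a step beyond the scatter remains open, since cyano is the only replacement for hydrogen shown here. Also open is whether cyano at this position would give a comparable step on the core of compound 2, where this assay starts from a much higher number, as the compounds shown include no such pair.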